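The source may hold more compounds than are shown below. What is called first, only, known or untested is meant among the compounds shown, and "the series" means these compounds.

Measured so far:
compound 1, `C[C@@H](NCC1CCN(CCCc2c[nH]c3ccc(-n4cnnc4)cc23)CC1)c1ccccc1` — in an assay on CHO cells for displacement of a labelled ligand from 5-hydroxytryptamine receptor 1D (Homo sapiens) (a higher number here means a weaker inhibitor, a lower number a stronger inhibitor), compound 1 gives 1.4 nM
compound 2, `c1ccc(NCC2CCN(CCCc3c[nH]c4ccc(-n5cnnc5)cc34)CC2)nc1` — in this assay compound 2 gives 1.7 nM

Compound 2 holds the higher of the two numbers, yet the step of a 1.2-fold higher number from compound 1 to compound 2 (0.08 log units; within the scatter) leaves the two compounds indistinguishable on this assay. Compound 3, `CC(=O)Nc1ccc(CNCC2CCN(CCCc3c[nH]c4ccc(-n5cnnc5)cc34)CC2)cc1`, is the next member of the series. Relative to compound 2 the change is 4-acetamidobenzyl in place of pyridin-2-yl on an amine nitrogen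

Among the compounds with values here, the single measured step bears on the same amine nitrogen: a 1.2-fold higher number from compound 1 to compound 2 (0.08 log units; within the scatter), a swap of one ring-bearing group for another without a shift beyond the scatter. Nothing in the series yet tests a group of the size of 4-acetamidobenzyl at this position, so the expectation rests on that one step alone and is held wide. On that basis compound 3 is expected at 3 nM, spanning 1 nM to 10 nM. The expected step is a 1.8-fold higher number from compound 2 to compound 3 (0.25 log units; within the scatter), most likely within the scatter.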

Compound 3, half-maximal inhibitory concentration: 4.2 nM
Beside the measured number, compound 3's estimate is 1.4-fold (0.15 log units) below it; low and high end bracket the measured number.
By their numbers in this assay, from the lowest: compounds 1 and 2 (each within the scatter of the next); then compound 3.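

In this assay the amine nitrogen now shows a change that goes beyond the scatter: 4-acetamidobenzyl gives a 2.5-fold higher number from compound 2 to compound 3 (0.39 log units; beyond the scatter) and a 3.0-fold higher number from compound 1 to compound 3 (0.48 log units; beyond the scatter), both modest steps. The earlier pair showed only that pyridin-2-yl and 1-phenylethyl could not be told apart here, whereas this result shows that the group on this nitrogen can shift the number, though compound 3 still reads 4.2 nM with the larger 4-acetamidobenzyl in place. Nothing at hand accounts for these steps.

Still open, going by these compounds, is which part of 4-acetamidobenzyl carries the step, a question that unsubstituted benzyl on the same nitrogen would address. Also open, on these data alone, is whether a carboxylic acid or a primary amine in place of the acetamido group would move the number further.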